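Bromo to trifluoromethyl on a triazolyl-bearing pyrazoline sulfonamide

A few compounds are considered here, and "the series" means these few. Any claim that something is new, unique, unknown or untested is made for them only; others in the source may bear on it.

Compound 1 `CN1CCN(c2ccc(C3=NN(S(=O)(=O)c4ccc(Br)cc4)C(c4ccc(N(C)C)cc4)C3)cc2)CC1`: 23.7%
Compound 2 `CN1CCN(c2ccc(C3=NN(S(=O)(=O)c4ccc(C(F)(F)F)cc4)C(c4ccc(N(C)C)cc4)C3)cc2)CC1`: 12.1%
Compound 3 `CN(C)c1ccc(C2CC(c3ccc(-n4cncn4)cc3)=NN2S(=O)(=O)c2ccc(Br)cc2)cc1`: 10.4%

In a functional assay on MDA-MB-231 cells (Homo sapiens) for inhibition, read by sulforhodamine B assay, tested at 10 uM (on this read-out higher numbers stand for more inhibition at the one concentration tested (going by the name of the read-out) and lower numbers for less inhibition), compound 1 gives 23.7%. Compound 2 differs from it by trifluoromethyl in place of bromo on an aromatic carbon, and that change gave a number 11.6 percentage points lower from compound 1 to compound 2 (beyond the scatter). Compound 3 carries a different core, the difference being (1H-1,2,4-triazol-1-yl in place of 4-methylpiperazin-1-yl on an aromatic carbon), with a number 13.3 percentage points lower from compound 1 to compound 3 (beyond the scatter). Compound 4 `CN(C)c1ccc(C2CC(c3ccc(-n4cncn4)cc3)=NN2S(=O)(=O)c2ccc(C(F)(F)F)cc2)cc1` is not yet measured; it differs from compound 3 by trifluoromethyl in place of bromo on an aromatic carbon, the same change as from compound 1 to compound 2, at the same place. Because of a number 11.6 percentage points lower from compound 1 to compound 2 (beyond the scatter), a step of similar direction is expected, though compound 3 at 10.4% leaves little room downward. For compound 4 the expected step is a number 7.4 percentage points lower from compound 3 to compound 4 (within the scatter). Compound 4 is thus estimated at 3%, between -8% and 14%.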

Compound 4, a percentage reported as inhibition, at one concentration (the size of the read-out at that concentration, not a potency): 15.3%
Compound 4: the middle estimate sits 12.3 percentage points below what was measured; the measured number lies above the stated range.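

In this assay, trifluoromethyl in place of bromo on the core bearing 1H-1,2,4-triazol-1-yl gave a number 4.9 percentage points higher from compound 3 to compound 4 (within the scatter), so the drop seen on the core bearing 4-methylpiperazin-1-yl did not carry over: the same change on two cores in this assay, a number 11.6 percentage points lower (beyond the scatter) from compound 1 to compound 2 and a number 4.9 percentage points higher (within the scatter) from compound 3 to compound 4, 16.5 percentage points apart, beyond the scatter of two such steps. Read the other way, 1H-1,2,4-triazol-1-yl in place of 4-methylpiperazin-1-yl on the trifluoromethyl compounds gave a number 3.2 percentage points higher from compound 2 to compound 4 (within the scatter), which likewise differs from the step on the bromo compounds: the same change on two cores in this assay, a number 13.3 percentage points lower (beyond the scatter) from compound 1 to compound 3 and a number 3.2 percentage points higher (within the scatter) from compound 2 to compound 4, 16.5 percentage points apart, beyond the scatter of two such steps. The two changes therefore do not act independently across these four compounds, but both new steps lie within the scatter, so this does not show that either change raises the number.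

The compounds shown leave open how a chloro group or a nitrile would behave in place of bromo. They also leave open whether a morpholine in place of 4-methylpiperazin-1-yl would follow the same pattern.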